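The source may report more compounds than this note shows. Statements on the series, on what has been measured and on what is new or still open speak of the compounds shown alone.

Compound 1 `CCCn1c(=O)c2[nH]c(-c3ccccc3)nc2n(CCSCC)c1=O` gives 191 nM in an assay on HEK293 cells for displacement of a labelled ligand from adenosine receptor A2b (Homo sapiens), read by scintillation counting; a lower number here means a stronger inhibitor, a higher number a weaker inhibitor. Compound 2 `CCSCCn1c(=O)n(CC)c(=O)c2[nH]c(-c3ccccc3)nc21` gives 479 nM in this assay.

Going by the values given here, compound 1 stands with the lower of the two numbers measured so far; its only neighbour is compound 2, reached by a 2.5-fold higher number from compound 1 to compound 2 (0.40 log units; beyond the scatter). Compound 3 `CCCn1c(=O)c2[nH]c(-c3ccccc3)nc2n(CC[S+]([O-])CC)c1=O` has not yet been measured. It differs from compound 1 by a group of 4 heavy atoms (2 carbon, 1 oxygen, 1 sulfur; no ring) in place of a group of 3 heavy atoms (2 carbon, 1 sulfur; no ring), on a saturated chain carbon, two bonds along the chain from an aromatic nitrogen. Among the compounds with values here, the single measured step, from compound 1 to compound 2, is a different kind of change, an exchange of methyl for hydrogen, so no measured step bears on the one from compound 1 to compound 3, and the data give no direct guide to its size or direction. In the absence of such a guide, a modest weakening is expected, estimated as a 2.1-fold higher number from compound 1 to compound 3 (0.32 log units; beyond the scatter) in this assay, with wide uncertainty. Compound 3 is therefore expected to give 400 nM (range 100 nM to 1600 nM) in this assay.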

Compound 3, inhibition constant: 589 nM
Compound 3: the middle estimate sits 1.5-fold (0.17 log units) below what was measured; measured number inside the range.
By their numbers in this assay, from the lowest: compound 1; then compounds 2 and 3 (each within the scatter of the next).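

In this assay, the change at this chain carbon, from ethylsulfanyl to the group of 4 heavy atoms that adds an oxygen on the sulfur, gives a 3.1-fold higher number from compound 1 to compound 3 (0.49 log units; beyond the scatter) and so leaves compound 1 with the lower number. Going by these compounds alone, the earlier step was an exchange of methyl for hydrogen on a different chain, so this is the first sign that the number also responds to a change at the sulfur-bearing chain, though only modestly. Nothing given here accounts for this shift.

Only these two groups are shown at this position, so it remains open where a sulfone, an ether or a longer chain would fall. On these data alone, it is also open whether the same oxygen on sulfur would give a step of similar size in compound 2.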